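This account rests on a few compounds, and the source may have more. Where it says the series, first, only, none or still open, it means among the compounds named here.

Measured compounds in a functional assay on NZB5 cells (Homo sapiens) for inhibition, read by thymidine incorporation, with a stated time of 5 days; a higher number here means a weaker inhibitor, a lower number a stronger inhibitor:
- compound 1 `Cc1ccc(Br)cc1S(=O)(=O)N(C)/N=C/c1cnn2ccc(C#N)cc12`: 700 nM
- compound 3 `Cc1ccc(NC(=O)C(F)(F)F)cc1S(=O)(=O)N(C)/N=C/c1cnn2ccc(C#N)cc12`: 2300 nM
- compound 2 `Cc1ccc([N+](=O)[O-])cc1S(=O)(=O)N(Cc1ccccc1)/N=C/c1cnn2ccc(C#N)cc12`: "not determined" (no result reported)

Compounds 1 and 3 share the same core and differ only on the aromatic ring that carries the sulfonamide; the change there gave a 3.3-fold higher number from compound 1 to compound 3 (0.52 log units; beyond the scatter). Compound 2 carries a nitro group on that ring and a benzyl group on the sulfonamide nitrogen, but for compound 2 there is no number in this assay, so it cannot be placed against compounds 1 and 3.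

Compound 4 `CCN(CC)CCN(/N=C/c1cnn2ccc(C#N)cc12)S(=O)(=O)c1cc([N+](=O)[O-])ccc1C` differs from compound 2 in one place: (diethylamino)methyl in place of phenyl on a saturated chain carbon bound to a sulfonamide nitrogen. Going by the values given here, none of the measured compounds differ from one another at the sulfonamide nitrogen, where compounds 1 and 3 both carry a methyl group, so the single measured step, from compound 1 to compound 3, concerns a different part of the molecule and does not bear on this change. There is therefore no measured basis for expecting a step in this assay in either direction, nor for ruling one out.

With that in mind, compound 4 is estimated to give about 1500 nM in this assay, with an expected range from 250 nM to 9000 nM.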

Compound 4, half-maximal inhibitory concentration: 3500 nM
Compound 4: the middle estimate sits 2.3-fold (0.37 log units) below what was measured; the range from low to high includes it.
By their numbers in this assay, from the lowest: compound 1; then compounds 3 and 4 (each within the scatter of the next).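

In this assay, going by these compounds alone, compound 4 gives 3500 nM but compound 2 has no number there, so no step from compound 2 to compound 4 can be read. The compounds shown leave open what the change from benzyl to 2-(diethylamino)ethyl does on its own in this assay and nothing at hand explains the value of compound 4.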